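The compounds below may be only part of what the source reports. "The series", "measured", "known", "first", "only" and "open" are said of these compounds alone.

In a functional assay on KB cells (Homo sapiens) for inhibition, read by sulforhodamine B assay, with a stated time of 72 h (on this read-out lower numbers stand for stronger inhibition of growth and higher numbers for weaker inhibition of growth), three compounds have been tested so far, and none has given a number. Compound 1 `CCOC(=O)/C=C/c1ccncc1-c1ccc2c(cnn2C)c1` shows > 10000 nM as its result, which is a limit of the assay. Compound 3 `CCOC(=O)/C=C/c1ccncc1-c1ccc2ccccc2c1` likewise shows > 10000 nM as a limit. Compound 2 `CNC(=O)/C=C/c1ccncc1-c1ccc2cc[nH]c2c1` also stands only at a limit, with > 10000 nM as its result. Together these results amount to the limit of > 10000 nM in this assay, at which 3 of the 3 values shown sit, and give no order among the three.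

Compound 4 `CCOC(=O)/C=C/c1ccncc1-c1ccc2cc[nH]c2c1` keeps the core of compound 2 and changes it in one place: ethoxy in place of methylamino on a carbonyl carbon with ethoxy in place of methylamino on a carbonyl carbon, so that methylcarbamoyl becomes ethoxycarbonyl. Among the compounds with values here, no measured pair shows this change directly. Compound 1 already carries the 2-(ethoxycarbonyl)ethenyl group and still has > 10000 nM as its limit. Compound 3 carries the same group and also has > 10000 nM as its limit. A large gain in this assay is therefore not expected, only a small move toward stronger inhibition of growth, if any. The expected change is an at least 1.2-fold lower number from compound 2 to compound 4 (0.09 log units; that floor lies within the scatter) and may well end at the same limit. The estimate for compound 4 is 8000 nM with an expected range of 1500 nM to 20000 nM in this assay.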

Compound 4, concentration for 50% growth inhibition: 7860 nM
Estimate against measurement, compound 4: 1.0-fold (0.01 log units) above; low and high end bracket the measured number.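

Compound 2 stands at > 10000 nM, which is a limit of the assay and not a number. Within the data shown here, on the carbonyl carbon whose other neighbour is the double-bonded chain carbon, ethoxy in place of methylamino gives the first number of the series, with compound 4 at 7860 nM, and in this assay this change reads as an at least 1.2-fold lower number from compound 2 to compound 4 (0.10 log units; that floor lies within the scatter). The number does not follow from the 2-(ethoxycarbonyl)ethenyl group alone, as compound 1 and compound 3 carry that group on other cores and give no number, and most of the set stays at the same limit: the limit of > 10000 nM in this assay, at which 3 of the 4 values shown sit.

Going by these compounds, because compound 2 has only a limit, the true size of the step remains open, and the printed floor cannot say how far methylcarbamoyl and ethoxycarbonyl lie apart. Also open, on these data alone, is how other groups on this carbonyl carbon would read on the core of compound 4, such as methoxy, dimethylamino, a carboxylic acid or a longer chain than ethoxy.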